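A few compounds are considered here, and "the series" means these few. Any claim that something is new, unique, unknown or untested is made for them only; others in the source may bear on it.

Compound 1 `Cc1cc2[nH]nc(N)c2c(=O)[nH]1`: 8%
Compound 2 `Cc1cc2c(c(N)nn2C)c(=O)[nH]1`: 5%

Both measured compounds were tested in an assay on isolated protein for inhibition of MAP kinase-activated protein kinase 5 (Homo sapiens), read by mobility shift assay, tested at 30 uM (on this read-out higher numbers stand for more inhibition at the one concentration tested (going by the name of the read-out) and lower numbers for less inhibition), and both show only weak inhibition. Within the data shown here, the one step among them, a number 3 percentage points lower from compound 1 to compound 2 (within the scatter), comes from a methyl in place of hydrogen on an aromatic nitrogen and lies within the scatter, so compound 2 sits on the same footing as compound 1 rather than below it.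

Compound 3 `Cn1nc(N)c2c(=O)[nH]c(-c3ccccc3)cc21` keeps the shared core of compound 2 and changes one group: phenyl in place of methyl on an aromatic carbon. Among the measured compounds shown here, no measured step concerns a phenyl or any change on this aromatic carbon; the only known step, which alters a group on an aromatic nitrogen, does not bear on it. The expectation therefore rests on the low level shown by compound 1 and compound 2 alone, with no evidence that a six-membered aromatic ring of carbon only at this place raises or lowers inhibition.

Compound 3 is expected to give about 8%, within a range of -5% to 25%. The step this estimate means, a number 3 percentage points higher from compound 2 to compound 3 (within the scatter), is expected to stay within the scatter.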

Compound 3, a percentage reported as inhibition, at one concentration (the size of the read-out at that concentration, not a potency): 11%
Compound 3: the middle estimate sits 3 percentage points below what was measured, within the range that was stated.
By their numbers in this assay, from the lowest: compounds 2, 1 and 3 (each within the scatter of the next).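

Phenyl in place of methyl on the aromatic carbon next to the ring nitrogen gives a number 6 percentage points higher from compound 2 to compound 3 (within the scatter) in this assay, so this is the first reading at this place rather than on the aromatic nitrogen. It shows that a group of 6 heavy atoms, with a six-membered aromatic ring of carbon only, can stand where a single carbon stood while the reading stays at the same weak level, so the size of the group at this place makes no visible difference across this one pair. No measurement shown here offers an explanation for this flat result.

Still open, as far as these compounds go, is whether any other group on this aromatic carbon, such as an amine, a carboxylic acid or a longer chain like butyl, would lift inhibition clear of the scatter. Also open, from the compounds shown here alone, is whether phenyl at this place would read the same with hydrogen instead of methyl on the aromatic nitrogen, as that would show whether the two places act independently.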